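Adding 4-methoxyphenyl to the core of compound 1

This account rests on a few compounds, and the source may have more. Where it says the series, first, only, none or still open, it means among the compounds named here.

Measured in a functional assay on MDA-MB-231 cells (Homo sapiens) for antiproliferative activity, read by spectrophotometry and resazurin assay, with a stated time of 72 h; on this read-out lower numbers stand for stronger inhibition and higher numbers for weaker inhibition:
- compound 1 `CC(=O)CC1Oc2cc(O)ccc2C=C1c1ccc(O)cc1`: 145000 nM
- compound 2 `CC(C)CC(=O)CC1Oc2cc(O)ccc2C=C1c1ccc(O)cc1`: 67000 nM
- compound 3 `O=C(CC1Oc2cc(O)ccc2C=C1c1ccc(O)cc1)c1ccccc1`: 88000 nM

Two measured steps start from compound 1. One shows a 2.2-fold lower number from compound 1 to compound 2 (0.34 log units; beyond the scatter), and the other shows a 1.6-fold lower number from compound 1 to compound 3 (0.22 log units; within the scatter). Compound 1 thus stands apart from compound 2 but not from compound 3, and the remaining step shows a 1.3-fold higher number from compound 2 to compound 3 (0.12 log units; within the scatter).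

Compound 4 `COc1ccc(C2=C(c3ccc(O)cc3)C(CC(C)=O)Oc3cc(O)ccc32)cc1` keeps the side chain of compound 1 and changes the core instead: 4-methoxyphenyl in place of hydrogen on a double-bonded ring carbon. It carries 4-methoxyphenyl in place of hydrogen on a double-bonded ring carbon. Going by the values given here, no measured step touches this place, so the three steps offer only indirect guidance. Both enlargements of the side chain gave small steps, the larger being a 2.2-fold lower number from compound 1 to compound 2 (0.34 log units; beyond the scatter). In this assay, a modest move to a lower number is therefore expected, though with little certainty, and the expected size is a 2.6-fold lower number from compound 1 to compound 4 (0.42 log units; beyond the scatter). Compound 4 is estimated at 55000 nM, with an expected range of 15000 nM to 150000 nM.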

Compound 4, half-maximal inhibitory concentration: 39000 nM
Compound 4: the middle estimate sits 1.4-fold (0.15 log units) above what was measured; low and high end bracket the measured number.
By their numbers in this assay, from the lowest: compounds 4, 2, 3 and 1 (each within the scatter of the next, the first and the last beyond it).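

In this assay, the double-bonded ring carbon next to the ring atom that bears a 4-hydroxyphenyl group accepts a large substituent: 4-methoxyphenyl in place of hydrogen gives a 3.7-fold lower number from compound 1 to compound 4 (0.57 log units; beyond the scatter). Going by these compounds alone, the earlier steps changed only the side chain, so this is the first sign that a change on the core of compound 1 itself can also move the number beyond the scatter. No measurement bears on why the number falls with this change.

As far as these compounds go, what a plain phenyl or an amine on this carbon would give remains open, and so does whether the methoxy group of the new substituent matters. Also open, from the compounds shown here alone, is whether the step would carry over to the isobutyl and phenyl side chains of compound 2 and compound 3.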